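This account rests on a few compounds, and the source may have more. Where it says the series, first, only, none or still open, it means among the compounds named here.

Measured so far:
compound 1 `CCN(CC)CN1C(=O)/C(=N/NC(N)=S)c2cc(Cl)ccc21` — > 100000 nM
compound 2 `CCN(CC)CN1C(=O)/C(=N/NC(=S)Nc2ccc(C)cc2)c2ccccc21` — 3800 nM
compound 3 `CCN(CC)CN1C(=O)/C(=N/NC(=S)Nc2ccc(C)cc2)c2cc(Cl)ccc21` — 17500 nM

Of the compounds shown here, three of one series have been tested in an ADME assay on CRFK cells (Felis catus) for cytotoxicity; on this read-out lower numbers stand for higher toxicity in this test and higher numbers for lower toxicity in this test. Compound 2 gives 3800 nM in this assay, the lowest of the two numbers recorded. Compound 3 gives 17500 nM. For compound 1 the result is a limit of this assay and not a number, > 100000 nM, as noted in the limit of > 100000 nM in this assay, at which 1 of the 3 values shown sits.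

The cores of compound 2 and compound 3 differ by hydrogen in place of chloro on an aromatic carbon; that change gives a 4.6-fold higher number from compound 2 to compound 3 (0.66 log units; beyond the scatter). The other change, (hydrogen in place of 4-methylphenyl on an amide-type nitrogen), yields an at least 5.7-fold higher number from compound 3 to compound 1 (0.75 log units; beyond the scatter), a step whose full size is hidden because compound 1 sits at the limit (the limit of > 100000 nM in this assay, at which 1 of the 3 values shown sits).

Compound 4 `CCN(CC)CN1C(=O)/C(=N/NC(N)=S)c2ccccc21` is not yet measured. It differs from compound 2 by hydrogen in place of 4-methylphenyl on an amide-type nitrogen, the same change that leads from compound 3 to compound 1, at the same place. Since compound 2 starts from 3800 nM, compound 4 is expected to move by a 7.9-fold higher number from compound 2 to compound 4 (0.90 log units; beyond the scatter) in this assay, resting on the size of an at least 5.7-fold higher number from compound 3 to compound 1 (0.75 log units; beyond the scatter). Compound 4 is thus estimated at 30000 nM, with a range from 10000 nM to 100000 nM.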

Compound 4, half-maximal cytotoxic concentration: 73800 nM
Compound 4: the middle estimate sits 2.5-fold (0.39 log units) below what was measured; low and high end bracket the measured number.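

In this assay, hydrogen in place of 4-methylphenyl on the amide-type nitrogen gives a 19-fold higher number from compound 2 to compound 4 (1.29 log units; beyond the scatter), so the change goes in the same direction on the cores with and without chloro: the same change on two cores in this assay, an at least 5.7-fold higher number (0.75 log units; beyond the scatter) from compound 3 to compound 1 and a 19-fold higher number (1.29 log units; beyond the scatter) from compound 2 to compound 4; the limit leaves it open whether they differ Compound 1 stands at > 100000 nM, which is a limit of the assay and not a number, so the pair shows the direction of the change but not whether its size carries from one core to the other. Hydrogen in place of chloro gives an at least 1.3-fold lower number from compound 1 to compound 4 (0.13 log units; that floor lies within the scatter), so this pair does not show whether the chloro step seen with 4-methylphenyl present also holds once that group is gone: the same change on two cores in this assay, a 4.6-fold higher number (0.66 log units; beyond the scatter) from compound 2 to compound 3 and an at least 1.3-fold higher number (0.13 log units; that floor lies within the scatter) from compound 4 to compound 1; the limit leaves it open whether they differ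

The compounds shown leave open how the number moves with other groups on that nitrogen, such as a methyl group, a plain phenyl or a longer alkyl chain. They also leave open whether fluoro or methoxy in place of chloro on the aromatic carbon would give a step like that of chloro.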